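Swapping a thiazole for an imidazole on a diaryl ether urea

This account rests on a few compounds, and the source may have more. Where it says the series, first, only, none or still open, it means among the compounds named here.

Measured so far:
compound 1 `O=C(Nc1ccccc1)Nc1ccc(Oc2ccc(-c3nccs3)cc2)cc1`: "not determined" (no result reported)
compound 2 `O=C(Nc1ccc(Oc2ccc(-c3nccs3)cc2)cc1)Nc1cc(Br)cc(C(F)(F)F)c1`: 81.7%

In a functional assay on A549 cells (Homo sapiens) for inhibition, read by MTT assay and WST assay, with a stated time of 72 h, tested at 10 uM (on this read-out lower numbers stand for less inhibition of growth and higher numbers for more inhibition of growth at the one concentration tested), compound 1 gives "not determined" (no result reported), so no number places it. Compound 2 carries a bromo-trifluoromethyl-substituted aryl ring instead of the plain phenyl of compound 1, and in this assay compound 2 gives 81.7%. Compound 3 `O=C(Nc1ccccc1)Nc1ccc(Oc2ccc(-c3ncc[nH]3)cc2)cc1` differs from compound 1 by 1H-imidazol-2-yl in place of 1,3-thiazol-2-yl on an aromatic carbon. For the measured compounds named here, no measured pair shows the effect of this exchange, so the size and direction of the step in this assay are open. Compound 3 is estimated at 45%, within 10% to 85%.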

Compound 3, percent growth inhibition at one concentration: 7.09%
Estimate against measurement, compound 3: 37.9 percentage points above, outside the stated range (below it).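

For the compounds shown here, compound 1 gives "not determined" (no result reported), so no step from it to compound 3 can be read. The compounds shown leave open what exchanging 1,3-thiazol-2-yl for 1H-imidazol-2-yl does to growth inhibition, and nothing here offers an explanation for the value of compound 3.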